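The source may report more compounds than this note shows. Statements on the series, on what has been measured and on what is new or still open speak of the compounds shown alone.

Compound 1 `COc1ccccc1/C=C/C(=O)OC/C=C/c1cc(OC)c(OC)cc1OC` was tested in a functional assay on the whole organism (strain Kunming) with Mus musculus as the target, with a stated time of 0.5 h, at a dose of 300 mg/kg by the intraperitoneal route (on this read-out lower numbers stand for a stronger effect and higher numbers for a weaker effect at the one dose given), where compound 1 gives 100%. Two related compounds were run alongside it: compound 2 `COc1cc(OC)c(OC)cc1/C=C/COC(=O)/C=C/c1c(OC)ccc(OC)c1OC` gives 100% in this assay, and compound 3 `COc1cc(OC)c(OC)cc1/C=C/COC(=O)/C=C/c1cc(OC)c(OC)c(OC)c1OC` gives 100% in this assay. Compound 1 thus stands level with compounds 2 and 3 at the digits shown, and the gaps among the three fall within the usual scatter of repeated measurements, so the data draw no distinction among them. Compound 4 `COc1cc(OC)c(OC)cc1/C=C/COC(=O)/C=C/c1cccc(Br)c1` has not yet been measured in this assay. Its structure departs from compound 1 in a single place: 3-bromophenyl in place of 2-methoxyphenyl on a double-bonded chain carbon bound to a double-bonded chain carbon. Within the data shown here, no measured pair in this set shows what such a swap does to the read-out, so there is no step to lean on. With the three measured compounds sharing one value, the change is expected to be small, no change at the digits printed from compound 1 to compound 4 (within the scatter), nothing beyond the scatter. Compound 4 is estimated to give 100% in this assay, within a range from 80% to 100%.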

Compound 4, a percentage reported as activity, at one dose (the size of the read-out at that dose, not a potency): 100%
For compound 4 middle estimate and measured number coincide at the digits printed, and the stated range covers the measured number.
By their numbers in this assay, from the lowest: compounds 1, 2, 3 and 4 (each within the scatter of the next).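

In this assay, among these compounds, the first comparison in this set that differs in a single place shows no change at the digits printed from compound 1 to compound 4 (within the scatter) when 3-bromophenyl takes the place of 2-methoxyphenyl on a double-bonded chain carbon bound to a double-bonded chain carbon. The group that leaves carries 1 hydrogen-bond acceptor and the group that enters carries 0, yet this read-out at the one dose given does not separate the two compounds. No supporting evidence bears on this result.

Going by these compounds, whether a different kind of group at this place, such as an amine or a carboxylic acid on the phenyl ring, would move the read-out remains open. So does whether a shorter or longer chain in place of the double-bonded chain would give a value different from that of compound 4, 100%.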